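A few compounds are considered here, and "the series" means these few. Any claim that something is new, unique, unknown or untested is made for them only; others in the source may bear on it.

Compound 1 `CNC(=O)[C@H](c1ccc(Cl)cc1)C(C)C`: 66%
Compound 2 `CC(C)[C@H](C(=O)Nc1ccccn1)c1ccc(Cl)cc1`: 92%
Compound 3 `CC(C)[C@H](C(=O)Nc1ccc(F)cn1)c1ccc(Cl)cc1`: 93%

In a functional assay on CHO cells for agonist activity at Free fatty acid receptor 2 (Homo sapiens), read by cAMP accumulation (on this read-out higher numbers stand for larger maximal responses and lower numbers for smaller maximal responses), compound 3 gives the highest of the three numbers, yet its margin over compound 2 is within the scatter a number 1 percentage points higher from compound 2 to compound 3 (within the scatter), while it lies clearly above compound 1 a number 27 percentage points higher from compound 1 to compound 3 (beyond the scatter). Compound 4 `CC(C)[C@H](C(=O)Nc1cccnn1)c1ccc(Cl)cc1` differs from compound 3 in one place: pyridazin-3-yl in place of 5-fluoropyridin-2-yl on an amide-type nitrogen. Within the data shown here, two measured steps bear on this: a number 26 percentage points higher from compound 1 to compound 2 (beyond the scatter) and a number 27 percentage points higher from compound 1 to compound 3 (beyond the scatter) show that an aromatic ring on the amide-type nitrogen, in place of methyl, brings a modest rise. Exchanging one such ring for another has not been measured, so compound 4 is expected to give a step within the scatter a number 5 percentage points lower from compound 3 to compound 4 (within the scatter). For compound 4 the estimate is 88%, ranging from 70% to 100%.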

Compound 4, largest response reached (reported as efficacy), in percent of the reference or control that the assay uses: 101%
Compound 4: the middle estimate sits 13 percentage points below what was measured, outside the stated range (above it).
By their numbers in this assay, from the lowest: compound 1; then compounds 2, 3 and 4 (each within the scatter of the next).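

In this assay, exchanging one aromatic ring for another on the amide-type nitrogen stays within the scatter: pyridazin-3-yl, with 2 ring hetero atoms, gives a number 8 percentage points higher from compound 3 to compound 4 (within the scatter) and a number 9 percentage points higher from compound 2 to compound 4 (within the scatter) and so cannot be told apart from either pyridine ring. Against methyl, the same ring gives a number 35 percentage points higher from compound 1 to compound 4 (beyond the scatter) and shows that the rise also holds for a ring with 2 hetero atoms. Nothing measured here explains these results. Still open, on these data alone, is whether a longer chain in place of methyl, or a ring carrying an amine or a carboxylic acid, would keep this response.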